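This account rests on a few compounds, and the source may have more. Where it says the series, first, only, none or still open, it means among the compounds named here.

Compound 1 `COc1cccc(N2C(=O)COc3ccc(-c4cnc(Cl)c(NS(=O)(=O)c5ccc(F)cc5)c4)cc32)c1`: > 40000 nM
Compound 2 `COc1ccc(N2C(=O)COc3ccc(-c4cnc5ccccc5c4)cc32)cc1`: > 40000 nM

Both readings come from a functional assay on HeLa cells (Homo sapiens) for antiproliferative activity, read by MTT assay, with a stated time of 72 h (on this read-out lower numbers stand for stronger inhibition and higher numbers for weaker inhibition), and neither gives a number. For compound 1, > 40000 nM is a limit of the assay. As far as these compounds go, for compound 2, > 40000 nM is likewise a limit, so its true position is unknown. Compound 3 `O=C1COc2ccc(-c3cnc4ccccc4c3)cc2N1c1ccccc1` carries hydrogen in place of methoxy on an aromatic carbon, turning 4-methoxyphenyl into phenyl: hydrogen in place of methoxy on an aromatic carbon. Going by the values given here, no measured step shows what this change does, and no shift beyond the scatter is expected in this assay. The estimated step, a number no higher from compound 2 to compound 3 (the limit leaves the size open), is expected to be small. For compound 3, the expected value is 40000 nM, with an estimated range of 15000 nM to 80000 nM.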

Compound 3, half-maximal inhibitory concentration: > 40000 nM
Compound 3: only a limit was reported (the forecaster's own chance of this, stated with the estimate: 75%); the middle value lies on the limit itself.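

Going by these compounds alone, compound 2 and compound 3 both stand at a limit, so no step between them can be read: the limit of > 40000 nM in this assay, at which 3 of the 3 values shown sit. The compounds shown leave open whether hydrogen in place of methoxy changes activity at all, and how far each compound lies past the limit.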